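Dechlorination of compound 3 in the cytotoxicity series

A few compounds are considered here, and "the series" means these few. Any claim that something is new, unique, unknown or untested is made for them only; others in the source may bear on it.

Three members of the series have been run in an ADME assay on MT2 cells (Homo sapiens) for cytotoxicity, read by MTT assay; a lower number here means that less compound is tolerated, a higher number that more compound is tolerated. Compound 1 `N#Cc1cc2c(Oc3ccccc3OCCn3ccc(=O)[nH]c3=O)cc(F)cn2c1` gives 40000 nM. Compound 2 `N#Cc1cc2c(Oc3ccc(F)cc3OCCn3ccc(=O)[nH]c3=O)cccc2o1` reaches only a limit of this assay, > 100000 nM. Compound 3 `N#Cc1cc2c(Oc3ccccc3OCCn3ccc(=O)[nH]c3=O)cc(Cl)cc2o1` likewise stands at a limit rather than a number, > 100000 nM. It therefore sits at the limit of > 100000 nM in this assay, at which 2 of the 3 values shown sit, and cannot be ordered against compound 2. Among the measured compounds shown here, no step between measured compounds is available in this assay. Compound 4 `N#Cc1cc2c(Oc3ccccc3OCCn3ccc(=O)[nH]c3=O)cccc2o1` differs from compound 3 by hydrogen in place of chloro on an aromatic carbon. Since compound 3 is known only as a limit, the step of a number no higher from compound 3 to compound 4 (the limit leaves the size open) is expected to be flat, none beyond the scatter. Compound 4 is thus estimated near 100000 nM, within 40000 nM to 250000 nM, with a fair chance of another limit.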

Compound 4, half-maximal cytotoxic concentration: > 100000 nM
Compound 4: no number, only a limit; the forecaster's own chance of this, stated with the estimate: 60%; the middle value lies on the limit itself.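

Among the compounds shown here, compound 2, compound 3 and compound 4 all stand at one limit, so no step to compound 4 can be read: the limit of > 100000 nM in this assay, at which 3 of the 4 values shown sit.

Still open, from the compounds shown here alone, is whether hydrogen in place of chloro or fluoro on an aromatic carbon changes the half-maximal cytotoxic concentration at all.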